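Dimethylamino in Place of Phenoxy: Expecting Compound 4

The source may hold more compounds than are shown below. What is called first, only, known or untested is meant among the compounds shown, and "the series" means these compounds.

Three compounds from this study were tested in a functional assay on UO-31 cells (Homo sapiens) for inhibition, read by sulforhodamine B assay, with a stated time of 48 h; on this read-out lower numbers stand for stronger inhibition of growth and higher numbers for weaker inhibition of growth. Compound 1 `COc1cc(C)cc(-c2c(-c3ccnc(-c4ccc(C(C)=O)cc4)c3)cnn2CC#N)c1` gives 2610 nM in this assay. Compound 2 `COc1cc(C)cc(-c2nn(CC#N)cc2-c2ccc(-c3cccc(C(C)=O)c3)nc2)c1` gives 3180 nM in this assay. Compound 3 `Cc1cc(O)cc(-c2nn(CC#N)cc2-c2ccnc(-c3ccc(Oc4ccccc4)cc3)c2)c1` gives 2180 nM in this assay. Compound 3 carries the smallest of the three numbers, but its gap to compound 1 and its gap to compound 2 both lie within the usual scatter of repeated measurements, so the three compounds cannot be told apart on these data.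

Compound 4 `Cc1cc(O)cc(-c2nn(CC#N)cc2-c2ccnc(-c3ccc(N(C)C)cc3)c2)c1` has not yet been measured. It differs from compound 3 in one place: dimethylamino in place of phenoxy on an aromatic carbon. Among the measured compounds shown here, no pair among the measured compounds differs in only one place, so there is no measured step to lean on for this change. In the absence of such a step, the expectation for compound 4 is a number close to that of compound 3, with no step beyond the scatter in either direction. Compound 4 is therefore estimated at 2200 nM in this assay, within a range from 900 nM to 5500 nM, which corresponds to an expected step of a 1.0-fold higher number from compound 3 to compound 4 (0.00 log units; within the scatter).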

Compound 4, concentration for 50% growth inhibition: 3230 nM
Compound 4: the middle estimate sits 1.5-fold (0.17 log units) below what was measured; the range from low to high includes it.
By their numbers in this assay, from the lowest: compounds 3, 1, 2 and 4 (each within the scatter of the next).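

In this assay, among the compounds shown here, dimethylamino in place of phenoxy on an aromatic carbon, para to a large group, gives the first step that can be read for a change in one place: a 1.5-fold higher number from compound 3 to compound 4 (0.17 log units; within the scatter). The change removes a group of 7 heavy atoms with a six-membered aromatic ring of carbon only and brings in one of 3 heavy atoms with no ring, yet the step stays within the scatter, so on this one pair the phenoxy ring is not needed to keep the number in the range seen for the other compounds. No accompanying measurement speaks to what lies behind this result.

On these data alone, it remains open whether any group at this place can move the number beyond the scatter in either direction, for instance a carboxylic acid, a morpholine or a primary amine. Also open, as far as these compounds go, is how the methoxy and acetyl groups of compound 1 and compound 2 contribute, since those compounds differ from compound 3 and compound 4 in more than one place and no step can be read for them.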